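The source may report more compounds than this note shows. Statements on the series, on what has been measured and on what is new or still open speak of the compounds shown alone.

Working notes on the series. All three measured compounds share one core and differ only in the aryl group on the amino nitrogen. In a functional assay on cells (Panel breast (Carcinoma cell lines), Homo sapiens) for inhibition, read by sulforhodamine B assay, with a stated time of 48 h (on this read-out higher numbers stand for lower toxicity in this test and lower numbers for higher toxicity in this test), compound 1 `CN1CCN(CCCOc2cccc3nc(Nc4ccc(Cl)c(C(F)(F)F)c4)ccc23)CC1` gives 11200 nM. Compound 2 `CN1CCN(CCCOc2cccc3nc(Nc4ccc(Cl)c(F)c4)ccc23)CC1` gives 13200 nM in this assay, and the step of a 1.2-fold higher number from compound 1 to compound 2 (0.07 log units; within the scatter) is within the scatter. Compound 3 `CN1CCN(CCCOc2cccc3nc(Nc4cc(Cl)cc(Cl)c4)ccc23)CC1` gives 21800 nM in this assay. Where compound 3 stands: the steps of a 1.9-fold higher number from compound 1 to compound 3 (0.29 log units; within the scatter) and a 1.7-fold higher number from compound 2 to compound 3 (0.22 log units; within the scatter) are both within the scatter, so on the numbers shown compound 3 cannot be told apart from compound 1 or compound 2.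

Compound 4 `CN1CCN(CCCOc2cccc3nc(Nc4cccc(Cl)c4)ccc23)CC1` is not yet measured in this assay. Relative to compound 3 the change is hydrogen in place of chloro on an aromatic carbon, meta to a chloro group and meta to a large group. For the measured compounds named here, the steps that bear on it are those that alter the same aryl ring, namely the steps to compound 3 from compound 1 and from compound 2; both are within the scatter. No step beyond the scatter is therefore expected in this assay, in either direction. The expected number for compound 4 is 18000 nM, with a range from 8000 nM to 40000 nM, which amounts to an expected step of a 1.2-fold lower number from compound 3 to compound 4 (0.08 log units; within the scatter).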

Compound 4, concentration lethal to 50% of the cells: 20800 nM
The estimate for compound 4 lay 1.2-fold (0.06 log units) below the measured number; the measured number falls inside the stated range.
By their numbers in this assay, from the lowest: compounds 1, 2, 4 and 3 (each within the scatter of the next).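

In this assay the series now holds a step that takes a substituent off the aryl ring and puts only hydrogen in its place: at this position, meta to a chloro group and meta to a large group, the change gives a 1.0-fold lower number from compound 3 to compound 4 (0.02 log units; within the scatter) and so has no readable effect on the number, with the 3-chlorophenyl group retaining one chloro. The comparisons with the other aryl groups give a 1.6-fold higher number from compound 2 to compound 4 (0.20 log units; within the scatter) and a 1.9-fold higher number from compound 1 to compound 4 (0.27 log units; within the scatter), so 3-chlorophenyl on the amino nitrogen cannot be told apart from 4-chloro-3-fluorophenyl or 4-chloro-3-(trifluoromethyl)phenyl on these numbers, and all four compounds remain within the scatter of the next in order. Nothing further is available to account for this result.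

The compounds shown leave open whether removing the remaining chloro group to give an unsubstituted phenyl, or placing a carboxylic acid or an amine on this ring, would produce a step beyond the scatter. They also leave open whether a longer chain between the shared core and the terminal amine would move the number, since every change shown lies on the aryl ring.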